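The compounds below may be only part of what the source reports. "The series", "measured", "known", "first", "only" and "open" are said of these compounds alone.

Compound 1 `Fc1ccc(/C=C\c2cc3ccccc3nc2Cl)cc1` - 24000 nM
Compound 2 `COc1ccc2nc(Cl)c(/C=C\c3ccc(C(F)(F)F)cc3)cc2c1` - 22800 nM
Compound 3 `COc1ccc2nc(Cl)c(/C=C/c3ccc(C(F)(F)F)cc3)cc2c1` - 48800 nM

All three were tested in a functional assay on MDA-MB-231 cells (Homo sapiens) for antiproliferative activity, read by sulforhodamine B assay, with a stated time of 72 h; on this read-out lower numbers stand for stronger inhibition and higher numbers for weaker inhibition. Compound 3 gives the highest number of the three. Compound 4 `COc1ccc2nc(Cl)c(/C=C/c3ccc(F)cc3)cc2c1` is not yet measured and departs from compound 3 in one group: fluoro in place of trifluoromethyl on an aromatic carbon. Among the measured compounds shown here, the only measured step, a 2.1-fold higher number from compound 2 to compound 3 (0.33 log units; beyond the scatter), concerns (the fact that compounds 2 and 3 differ only in the configuration as drawn), so it does not test this swap. Compound 1 carries fluoro and gives 24000 nM, and compound 2 carries trifluoromethyl and gives 22800 nM. These values sit close together, although those compounds differ elsewhere too. No clear change is therefore expected, and the estimated step is a 1.2-fold lower number from compound 3 to compound 4 (0.09 log units; within the scatter). For compound 4 the expected value is 40000 nM, within an estimated range of 17000 nM to 90000 nM.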

Compound 4, half-maximal inhibitory concentration: 11000 nM
Beside the measured number, compound 4's estimate is 3.6-fold (0.56 log units) above it; measured number below the stated range.
By their numbers in this assay, from the lowest: compound 4; then compounds 2 and 1 (each within the scatter of the next); then compound 3.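

In this assay fluoro in place of trifluoromethyl gives a 4.4-fold lower number from compound 3 to compound 4 (0.65 log units; beyond the scatter) on this aromatic carbon, para to a large group. Among the compounds shown here, the earlier compounds carrying these two groups differ elsewhere too, whereas here the swap is the only change, so the number does respond to the group at this place. Nothing measured here explains why the fluoro compound gives the lower number.

Going by these compounds, whether the same swap acts alike with the double bond drawn Z stays open. So does the outcome with other groups at this place, such as an amine or a carboxylic acid.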